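Compound 4: Isopropoxy Variant of Compound 1

This account rests on a few compounds, and the source may have more. Where it says the series, first, only, none or still open, it means among the compounds named here.

Of the compounds shown here, three from one series have been tested in an in vitro functional assay on SH-EP1 cells for agonist activity at Neuronal acetylcholine receptor; alpha4/beta2 (Homo sapiens), read by FLIPR and calcium flux; on this read-out lower numbers stand for an effect already at smaller amounts and higher numbers for an effect only at larger amounts of compound. Compound 1 `COc1cncc(C2=CC3CC(C2)CN(C)C3)c1` gives 5130 nM in this assay. Compound 2 `C1=C(c2ccc(-c3ccccc3)nc2)CC2CNCC1C2` gives 9660 nM, and compound 3 `COc1cncc(C2=CC3CNCC(C2)C3)c1` gives 53 nM. Among these three numbers compound 1 stands second highest; its nearest neighbour is compound 2, whose value lies within the usual scatter of that of compound 1, so no order between the two can be claimed, while compound 3 lies well beyond the scatter on the lower side. Among the compounds with values here, the only step between two compounds that differ in a single place is a 97-fold lower number from compound 1 to compound 3 (1.99 log units; beyond the scatter), where hydrogen replaces methyl on an amine nitrogen in a ring.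

Compound 4 `CC(C)Oc1cncc(C2=CC3CC(C2)CN(C)C3)c1` has not yet been measured. It differs from compound 1 by isopropyl in place of methyl on an oxygen on an aromatic ring. Within the data shown here, none of the measured steps touches this oxygen: the one large step concerns the ring nitrogen instead, and compound 2 differs from compound 1 in several places at once. With nothing that bears directly on the change, a step no larger than the scatter is expected, leaning if anything toward a slightly higher number. For compound 4 the estimate in this assay is 6500 nM, within a range from 2000 nM to 22000 nM, which corresponds to an expected step of a 1.3-fold higher number from compound 1 to compound 4 (0.10 log units; within the scatter).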

Compound 4, half-maximal effective concentration: > 10000 nM
Compound 4: only a limit was reported; the forecaster's own chance of this, stated with the estimate: 15%; at least 1.5-fold (0.18 log units) between middle value and limit.
By their numbers in this assay, from the lowest: compound 3; then compounds 1 and 2 (each within the scatter of the next). At a limit, above all of these: compound 4.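

Within the data shown here, this is the first reading at the oxygen on the aromatic ring: all the earlier single-place information concerned the amine nitrogen in the ring. In this assay compound 4 gives > 10000 nM, which is a limit and not a number. Going from methoxy to isopropoxy on the shared core gives an at least 1.9-fold higher number from compound 1 to compound 4 (0.28 log units; that floor lies within the scatter), so this larger group brought no lower number, but the step can be read only as a floor, and that floor does not by itself separate the two compounds beyond the scatter, because the reading ends at a limit: the limit of > 10000 nM in this assay, at which 1 of the 4 values shown sits.

Open, as far as these compounds go, is how a group of a different size on this oxygen would read, whether an ethyl in place of the isopropyl or a hydrogen that leaves a hydroxyl, and so whether the number climbs gradually or abruptly with the size of the group. Also open, from the compounds shown here alone, is whether isopropoxy would read differently with hydrogen on the ring nitrogen, the change that gave a 97-fold lower number from compound 1 to compound 3 (1.99 log units; beyond the scatter) with methoxy in place.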